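Two Steps Measured, One Step Still Expected

The source may hold more compounds than are shown below. What is called first, only, known or untested is meant among the compounds shown, and "the series" means these compounds.

In a functional assay on the whole organism (strain Wistar albino) for inhibition, with Rattus norvegicus as the target, read by paw edema, with a stated time of 1 h, at a dose of 40 mg/kg by the oral route (a lower number here means less inhibition, a higher number more inhibition at the dose given (going by the name of the read-out)), compound 3 `Cc1nc(Cc2ccc(Cl)cc2)sc1C1SCC(=O)N1c1ccc(Cl)cc1` gives 48.9%. Compound 2 `Cc1nc(-c2ccc(Cl)cc2)sc1C1SCC(=O)N1c1ccc(Cl)cc1` differs from compound 3 by 4-chlorophenyl in place of 4-chlorobenzyl on an aromatic carbon, and in this assay compound 2 gives 69.3%, which corresponds to a number 20.4 percentage points lower from compound 2 to compound 3 (beyond the scatter). Compound 1 `Cc1ccc(N2C(=O)CSC2c2sc(Cc3ccc(Cl)cc3)nc2C)cc1` differs from compound 3 by methyl in place of chloro on an aromatic carbon, and in this assay compound 1 gives 59.9%, a change of a number 11 percentage points higher from compound 3 to compound 1 (beyond the scatter). Compound 4 `Cc1ccc(N2C(=O)CSC2c2sc(-c3ccc(Cl)cc3)nc2C)cc1` has not yet been measured; it differs from compound 2 by methyl in place of chloro on an aromatic carbon, the same change that separates compound 3 from compound 1, made at an identically described place. Compound 4 is expected to show a step of a number 7.7 percentage points higher from compound 2 to compound 4 (within the scatter) in this assay, a modest rise, because the same change once gave a number 11 percentage points higher from compound 3 to compound 1 (beyond the scatter) from a lower starting point. Compound 4 is therefore estimated at 77% in this assay, with a plausible range from 64% to 88%.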

Compound 4, a percentage reported as inhibition, in the whole organism at one dose (the size of the read-out at that dose, not a potency): 38.3%
Beside the measured number, compound 4's estimate is 38.7 percentage points above it; the whole stated range lies above it.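

In this assay, methyl in place of chloro gave a number 31 percentage points lower from compound 2 to compound 4 (beyond the scatter), so this change did not carry over from one core to the other: the same change on two cores in this assay, a number 11 percentage points higher (beyond the scatter) from compound 3 to compound 1 and a number 31 percentage points lower (beyond the scatter) from compound 2 to compound 4, 42 percentage points apart, beyond the scatter of two such steps

The change between the 4-chlorophenyl and 4-chlorobenzyl groups did not carry over either, with 4-chlorophenyl in place of 4-chlorobenzyl giving a number 21.6 percentage points lower from compound 1 to compound 4 (beyond the scatter), and the step on the other core running the opposite way: the same change on two cores in this assay, a number 20.4 percentage points lower (beyond the scatter) from compound 2 to compound 3 and a number 21.6 percentage points higher (beyond the scatter) from compound 4 to compound 1, 42 percentage points apart, beyond the scatter of two such steps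

So across these four compounds the two places do not act independently, but this rests on a single set of four compounds at one dose and time, and it does not show why the steps reverse.

The compounds shown leave open how a methoxy group or an amine in place of chloro or methyl would behave. They also leave open whether a longer chain would follow the 4-chlorobenzyl or the 4-chlorophenyl compounds.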